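The source may hold more compounds than are shown below. What is called first, only, known or untested is meant among the compounds shown, and "the series" means these compounds.

Compound 1 `Cc1ccccc1NC(=O)N[C@H](C)c1ccccc1` and compound 2 `CCc1ccccc1NC(=O)N[C@H](C)c1ccccc1` share one core and differ only in the chain on the aromatic ring. In an ADME assay on the whole organism with Oryza sativa as the target, tested at 10 uM (on this read-out lower numbers stand for a stronger effect and higher numbers for a weaker effect at the one concentration tested), compound 1 gives 99%, and in this assay compound 2 gives 92%. The step of a number 7 percentage points lower from compound 1 to compound 2 (within the scatter) is therefore small, and compound 2 stands with the lower of the two numbers while still within the scatter of compound 1. Compound 3 `CC(C)c1ccccc1NC(=O)N[C@H](C)c1ccccc1` carries the same core and differs from compound 2 by methyl in place of hydrogen on a saturated chain carbon bound to an aromatic carbon and a saturated chain carbon. For the measured compounds named here, the only measured step that bears on this change is a number 7 percentage points lower from compound 1 to compound 2 (within the scatter), which added a methyl at the same kind of place and did not move the read-out beyond the scatter. A step of similar size, or none beyond the scatter, is therefore expected from compound 2 to compound 3, namely a number 4 percentage points lower from compound 2 to compound 3 (within the scatter). For compound 3 the estimate in this assay is 88%, within a range from 74% to 100%.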

Compound 3, a percentage reported as activity, at one concentration (the size of the read-out at that concentration, not a potency): 17%
Estimate against measurement, compound 3: 71 percentage points above; the whole stated range lies above it.
By their numbers in this assay, from the lowest: compound 3; then compounds 2 and 1 (each within the scatter of the next).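

In this assay the second methyl on the saturated chain carbon bound to an aromatic carbon does what the first did not: the change from ethyl to isopropyl gives a number 75 percentage points lower from compound 2 to compound 3 (beyond the scatter) and so lies beyond the scatter, whereas the earlier added methyl stayed within it. Isopropyl in place of methyl on an aromatic carbon likewise gives a number 82 percentage points lower from compound 1 to compound 3 (beyond the scatter) and so the read-out does not follow the added carbons evenly across these three compounds, with only the isopropyl compound standing apart. No measurement at hand accounts for this abrupt change at this one place.

On these data alone, it remains open whether the branch itself matters or the chain length alone, which a propyl chain or a longer chain on the same aromatic carbon would address. A tert-butyl group there would show whether further branching keeps, deepens or loses the low number.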